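The compounds below may be only part of what the source reports. "The series", "measured", "known", "first", "only" and "open" are said of these compounds alone.

Compound 1 `ClCc1ccc(Cn2cnc3c(Cl)ncnc32)cc1` and compound 2 `ClCc1cccc(Cn2cnc3ncnc(Cl)c32)c1` are built on the same core, joined to a benzyl arm that carries a chloromethyl group. In a functional assay on SNB-19 cells (Homo sapiens) for cytotoxicity, read by sulforhodamine B assay, with a stated time of 48 h (a lower number here means that less compound is tolerated, a higher number that more compound is tolerated), compound 1 gives 89100 nM, the highest of the two numbers, while compound 2 gives 6760 nM, a lower number beyond the usual scatter. Compound 3 `ClCc1ccc(Cn2cnc3c(Cl)nc(Cl)nc32)cc1` has not yet been measured in this assay; it differs from compound 1 by chloro in place of hydrogen on an aromatic carbon. Among the measured compounds shown here, no comparable step exists among the measured compounds, so the expected change is uncertain, and only a modest move toward a lower number is expected, a 1.8-fold lower number from compound 1 to compound 3 (0.25 log units; within the scatter). Compound 3 is therefore estimated at 50000 nM, within a range from 15000 nM to 150000 nM.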

Compound 3, concentration lethal to 50% of the cells: > 100000 nM
Compound 3 was reported as a limit; the forecaster's own chance of this, stated with the estimate: 10%; middle value at least 2.0-fold (0.30 log units) from the limit.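

In this assay, compound 3 gives > 100000 nM, which is a limit of the assay and not a number. Chloro in place of hydrogen on this aromatic carbon, between two ring nitrogen atoms, gives an at least 1.1-fold higher number from compound 1 to compound 3 (0.05 log units; that floor lies within the scatter), so the expected move toward a lower number does not appear. This step therefore gives a floor and no size: the limit of > 100000 nM in this assay, at which 1 of the 3 values shown sits.

Going by these compounds, whether an amine or a methoxy group on this same carbon would shift the number remains open. So does what chloro here would do on the core of compound 2.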